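The compounds below may be only part of what the source reports. "The series", "measured", "known", "first", "only" and "open" are said of these compounds alone.

Measured compounds:
- Compound 1, `O=C(Nc1cccc(Oc2ccccn2)c1)C1CCCN(C(=O)c2cc(C(F)(F)F)cc(C(F)(F)F)c2)C1`: in an ADME assay on PC-3 cells (Homo sapiens) for cytotoxicity, read by WST assay, tested at 100 uM (a lower number here means less inhibition, a higher number more inhibition at the concentration tested (going by the name of the read-out)), compound 1 gives 0%
- Compound 2, `COC(=O)c1cccc(NC(=O)C2CCCN(C(=O)c3cc(C(F)(F)F)cc(C(F)(F)F)c3)C2)c1`: in this assay compound 2 gives 0%

Compound 2 therefore stands level with compound 1 in this assay, both showing no measurable inhibition of these prostate cancer cells at the single concentration tested. For the measured compounds named here, the one step measured so far, no change at the digits printed from compound 1 to compound 2 (within the scatter), was flat within the scatter, even though it swapped one substituent on the aromatic ring for a quite different one.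

Compound 3, `COC(=O)c1cc(-c2cccc(NC(=O)C3CCCN(C(=O)c4cc(C(F)(F)F)cc(C(F)(F)F)c4)C3)c2)co1`, is not yet measured. Compared with compound 2 it carries 5-(methoxycarbonyl)furan-3-yl in place of methoxycarbonyl on an aromatic carbon, so the substituent grows from a small ester into a five-membered aromatic ring that still bears the methoxycarbonyl group. Going by the values given here, no measured step involves a change of this kind, so the flat step from compound 1 to compound 2 is the only guide, and it suggests that substituents at this place have not moved the read-out. The expected step of a number 3 percentage points higher from compound 2 to compound 3 (within the scatter) is therefore none beyond the scatter. Compound 3 is estimated at 3% in this assay, with a range from 0% to 20%.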

Compound 3, a percentage reported as inhibition, at one concentration (the size of the read-out at that concentration, not a potency): 0%
Estimate against measurement, compound 3: 3 percentage points above; the measured number falls inside the stated range.
By their numbers in this assay, from the lowest: compounds 1, 2 and 3 (each within the scatter of the next).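

In this assay, the result of exchanging methoxycarbonyl for the much larger 5-(methoxycarbonyl)furan-3-yl, which brings in a five-membered aromatic ring, is no change at the digits printed from compound 2 to compound 3 (within the scatter) and the ester survives on the new ring. Set against the (pyridin-2-yl)oxy group, the same furan substituent gives no change at the digits printed from compound 1 to compound 3 (within the scatter), so three quite different groups on this aromatic carbon, meta to a large group, now read alike, and the size of the substituent, across this range, has not shifted the result. The data offer no explanation for this flat outcome.

All three compounds share the same core and differ only at this one place, so they leave open whether a group of another kind there, such as an amine or a carboxylic acid in place of the methyl ester, would give a different reading. They also leave open whether changes elsewhere in the shared core, such as removing a trifluoromethyl group, would move the read-out in these cells at this single concentration.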